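A few compounds are considered here, and "the series" means these few. Any claim that something is new, unique, unknown or untested is made for them only; others in the source may bear on it.

The measured compounds and their values:

Compound 1, `O=C(Nc1cccc(-n2cc(-c3ccncc3)c(-c3ccc(Cl)c(O)c3)n2)c1)Nc1ccc(Cl)c(Cl)c1`: 1690 nM
Compound 2, `COc1cc(-c2nn(-c3cccc(NC(=O)c4cccc(C(F)(F)F)c4)c3)cc2-c2ccncc2)ccc1Cl`: 2280 nM
Compound 3, `O=C(Nc1cccc(-n2cc(-c3ccncc3)c(-c3ccc(Cl)c(O)c3)n2)c1)Nc1cc(C(F)(F)F)cc(C(F)(F)F)c1`: 849 nM

All three share one core and were tested in a functional assay on OVCAR-4 cells (Homo sapiens) for inhibition, read by sulforhodamine B assay, with a stated time of 48 h; a lower number here means a stronger inhibitor of growth, a higher number a weaker inhibitor of growth. Compound 2 has the highest number of the three. Compound 1 lies within the usual scatter of compound 2, so the two cannot be told apart on these numbers. Among the compounds with values here, compound 3, with its lower number, stands beyond the scatter from compound 2 and is the only pair here that shows a difference one can rely on.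

The next compound to consider is compound 4, `COc1cc(-c2nn(-c3cccc(NC(=O)c4ccccc4)c3)cc2-c2ccncc2)ccc1Cl`. It differs from compound 2 in a single place: hydrogen in place of trifluoromethyl on an aromatic carbon. The change removes a trifluoromethyl group and leaves a hydrogen in its place, so the amide carries a plain benzoyl rather than a (3-(trifluoromethyl)phenyl)carbonyl.

Within the data shown here, no measured pair shows this particular change, so there is nothing to set the size of the step against. On that basis the step of a 1.2-fold higher number from compound 2 to compound 4 (0.09 log units; within the scatter) is expected to be small, and it may well stay within the scatter. Compound 4 is therefore estimated to give 2800 nM in this assay, with a range from 1200 nM to 7000 nM.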

Compound 4, concentration for 50% growth inhibition: 1170 nM
Beside the measured number, compound 4's estimate is 2.4-fold (0.38 log units) above it; measured number outside the range, below it.
By their numbers in this assay, from the lowest: compounds 3, 4, 1 and 2 (each within the scatter of the next, the first and the last beyond it).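

Within the data shown here, this is the first change that can be read in one place alone: in this assay, putting hydrogen in place of trifluoromethyl on the aromatic ring of the amide gives a 1.9-fold lower number from compound 2 to compound 4 (0.29 log units; within the scatter). Four heavy atoms leave, yet the two numbers cannot be told apart, so at this position the trifluoromethyl group is not shown to be needed for growth inhibition at this level, and the plain benzoyl serves as well within the limits of the measurement. Nothing measured here on either group accounts for this result.

A fluorine, a methoxy, an amine or a carboxylic acid at the same place on the ring would show whether this position accepts many different groups or whether the match between hydrogen and trifluoromethyl is special to that pair. Also open, as far as these compounds go, is whether removing a trifluoromethyl group from a urea compound such as compound 3 would give an equally small step.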